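A few compounds are considered here, and "the series" means these few. Any claim that something is new, unique, unknown or untested is made for them only; others in the source may bear on it.

Measured compounds in an assay on HL-60 cells for agonist activity at vitamin D3 receptor (Homo sapiens), read by microscopy, with a stated time of 96 h; on this read-out higher numbers stand for an effect only at larger amounts of compound and lower numbers for an effect already at smaller amounts:

compound 1 `CCn1c(C(=O)NCCCN(C)C)ccc1C(CC)(CC)c1ccc(OCC(=O)C(C)(C)C)c(C)c1`: 96 nM
compound 2 `C#CC(C)OC(=O)c1ccc(C(CC)(CC)c2ccc(OCC(=O)C(C)(C)C)c(C)c2)n1CC`: 210 nM

Among the compounds with values here, compound 2 gives the higher of the two numbers so far; its nearest neighbour is compound 1, with the step of a 2.2-fold higher number from compound 1 to compound 2 (0.34 log units; beyond the scatter). That step is the only one measured in the set, and it turns on the group attached to the carbonyl carbon on the shared core: an ester group in compound 2 against an amide group in compound 1.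

Compound 3 `CCn1c(C(=O)N(C)CC(=O)O)ccc1C(CC)(CC)c1ccc(OCC(=O)C(C)(C)C)c(C)c1` is not yet measured. It differs from compound 2 by (carboxymethyl)(methyl)amino in place of (1-methylprop-2-yn-1-yl)oxy on a carbonyl carbon. Within the data shown here, only the step from compound 1 to compound 2 bears on this change, and it went the other way: from an amide to an ester the number rose modestly. Compound 3 returns to an amide, though with a different substituent on the nitrogen than compound 1 carries, so a modest move back toward lower numbers is expected in this assay, with a 1.8-fold lower number from compound 2 to compound 3 (0.24 log units; within the scatter), and nothing larger can be supported by two compounds. Compound 3 is therefore estimated at 120 nM, with a range from 40 nM to 400 nM.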

Compound 3, half-maximal effective concentration: 1390 nM
Estimate against measurement, compound 3: 12-fold (1.06 log units) below; the measured number lies above the stated range.
By their numbers in this assay, from the lowest: compound 1; then compound 2; then compound 3.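

In this assay, the identity of the whole group on the carbonyl carbon matters more than whether it is joined through nitrogen or oxygen: the amide of compound 3 does not fall back toward the amide of compound 1 but passes the ester of compound 2 (a 6.6-fold higher number from compound 2 to compound 3 (0.82 log units; beyond the scatter)). The widest step in the series lies between the two amides (a 14-fold higher number from compound 1 to compound 3 (1.16 log units; beyond the scatter)), so this position separates compounds more strongly than the earlier ester and amide pair suggested. Among these three compounds, amide against ester therefore gives no consistent direction, with compound 1 lying on the lower side of compound 2 and compound 3 on the higher side, and no measurement available here explains the rise at this position.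

The change from compound 1 to compound 3 replaces the dimethylamino-bearing chain with a carboxylic acid-bearing one and also replaces the amide hydrogen with a methyl group on nitrogen, so the compounds shown do not assign the step to either feature. As far as these compounds go, a carboxymethylamino amide that keeps the amide hydrogen, or a methyl ester in place of the carboxylic acid, would separate these two features, and the effect of a longer chain between the amide nitrogen and the carboxylic acid also remains open.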